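Swapping the sulfonyl aryl group on a quinoline series

The source may hold more compounds than are shown below. What is called first, only, known or untested is meant among the compounds shown, and "the series" means these compounds.

Measured compounds:
- Compound 1, `COc1ccc(S(=O)(=O)c2cnc3ccc(C)cc3c2N2CCC(C)CC2)cc1Cl`: 93%
- Compound 2, `Cc1ccc(S(=O)(=O)c2cnc3c(F)cccc3c2N2CCC(C)CC2)cc1`: 93%
- Compound 3, `CC1CCN(c2c(S(=O)(=O)c3ccc(Cl)c(Cl)c3)cnc3ccc(Cl)cc23)CC1`: 86%

In an assay on isolated protein for displacement of a labelled ligand from metabotropic glutamate receptor 5 (Homo sapiens), with a stated time of 60 min, tested at 1 uM (a lower number here means less inhibition, a higher number more inhibition at the concentration tested (going by the name of the read-out)), compound 1 gives 93%, level at the digits shown with compound 2, which gives 93%; together these are the highest of the three numbers. Compound 3 gives 86%, a reading a few points lower, but the gap to compound 1 lies within the scatter, so no ordering of the three can be claimed.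

Compound 4, `Cc1ccc2ncc(S(=O)(=O)c3cccc(C#N)c3)c(N3CCC(C)CC3)c2c1`, has not yet been measured. It differs from compound 1 in one place: 3-cyanophenyl in place of 3-chloro-4-methoxyphenyl on a sulfonyl sulfur. Going by the values given here, no step between two measured compounds touches this sulfonyl aryl group, so nothing among the measured values shows how much it matters. The three measured compounds, which differ in several places at once, all sit at a high level in this assay, so the step is expected to be small, with no clear direction beyond the scatter.

Compound 4 is therefore estimated at 85%, with a range from 62% to 97%, which corresponds to an expected step of a number 8 percentage points lower from compound 1 to compound 4 (within the scatter).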

Compound 4, a percentage reported as inhibition, at one concentration (the size of the read-out at that concentration, not a potency): 52%
Compound 4: the middle estimate sits 33 percentage points above what was measured, and the stated range ends above it.
By their numbers in this assay, from the lowest: compound 4; then compounds 3, 1 and 2 (each within the scatter of the next).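

In this assay, going by these compounds alone, the swap of 3-chloro-4-methoxyphenyl for 3-cyanophenyl on the sulfonyl sulfur comes with a number 41 percentage points lower from compound 1 to compound 4 (beyond the scatter) and gives the first reading of this position in a single-place change. It shows that this aryl group can matter a great deal on the core of compound 1, and that the high level shared by the three earlier compounds does not hold for every group here. Nothing in the data shown bears on why the step is so large.

The step exchanges a whole aryl group, so the loss of the chlorine and the methoxy cannot be told apart from the arrival of the nitrile. As far as these compounds go, whether an unsubstituted phenyl group on the sulfonyl sulfur would stay near compound 1 or fall toward compound 4 remains open.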